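The source may hold more compounds than are shown below. What is called first, only, known or untested is meant among the compounds shown, and "the series" means these compounds.

In a functional assay on OVCAR-3 cells (Homo sapiens) for antiproliferative activity, read by WST assay, with a stated time of 72 h (on this read-out higher numbers stand for weaker inhibition of growth and lower numbers for stronger inhibition of growth), compound 1 `N=C(N)c1ccc(/N=N/Nc2cccc(C#Cc3ccccn3)c2)cc1` gives 10700 nM, the only exact figure available so far. In this assay compound 2 `C#Cc1ccccc1N/N=N/c1ccc(C(=N)N)cc1` gives > 25000 nM, which is a limit of the assay and not a number. Compound 3 `N=C(N)c1ccc(/N=N/Nc2cccc(C#Cc3ccc(F)cc3)c2)cc1` differs from compound 1 in one place: 4-fluorophenyl in place of pyridin-2-yl on a triple-bonded carbon. Going by the values given here, no measured step shows what this exchange does, so only a small gain in growth inhibition is expected in this assay, hardly beyond the usual scatter. The expected step is a 1.3-fold lower number from compound 1 to compound 3 (0.13 log units; within the scatter). For compound 3 the estimate is 8000 nM, with an expected range from 2500 nM to 25000 nM.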

Compound 3, concentration for 50% growth inhibition: 5000 nM
Beside the measured number, compound 3's estimate is 1.6-fold (0.20 log units) above it, and the stated range covers the measured number.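

On a triple-bonded carbon, 4-fluorophenyl in place of pyridin-2-yl gives, in this assay, a 2.1-fold lower number from compound 1 to compound 3 (0.33 log units; beyond the scatter). Going by these compounds alone, the earlier compounds offered no measured step at this place, so this is the first sign that growth inhibition responds to the ring held there. Nothing measured here explains the size of this step. On these data alone, whether the gain belongs to the fluorine or to the carbon-only ring stays open, and a plain phenyl group would separate the two. As far as these compounds go, the effect of a ring carrying an amine or a carboxylic acid also remains unknown.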